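A few compounds are considered here, and "the series" means these few. Any claim that something is new, unique, unknown or untested is made for them only; others in the source may bear on it.

Measured so far in an ADME assay on L02 cells (Homo sapiens) for cytotoxicity, read by MTT assay; a lower number here means a stronger inhibitor, a higher number a weaker inhibitor:
compound 1 `COc1ccc(/C=C/C(=O)c2ccc(OC)c3c2OC(C)(C)C=C3)cc1OCCO`: > 10000 nM
compound 2 `COc1ccc(/C=C/C(=O)c2ccc(OC)c3c2OC(C)(C)C=C3)cc1OCCCN(C)C`: 8600 nM
compound 3 `C=CC(=O)Oc1cc(/C=C/C(=O)c2ccc(OC)c3c2OC(C)(C)C=C3)ccc1OC`: > 10000 nM

Compound 3 gives > 10000 nM, which is a limit and not a number. Compound 1 gives > 10000 nM, which is also a limit. Compound 3 therefore stands at the limit of > 10000 nM in this assay, at which 2 of the 3 values shown sit. Only compound 2 has a true number, 8600 nM.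

Compound 4 `COc1cccc(C(=O)Oc2cc(/C=C/C(=O)c3ccc(OC)c4c3OC(C)(C)C=C4)ccc2OC)c1` keeps the core of compound 3 and has 3-methoxyphenyl in place of vinyl on a carbonyl carbon.

Among the measured compounds shown here, no measured step makes this exchange. The nearest ones are exchanges on an oxygen on an aromatic ring: an at least 1.1-fold higher number from compound 2 to compound 3 (0.06 log units; that floor lies within the scatter) and a step that the two limits leave unreadable from compound 1 to compound 3. The remaining step, an at least 1.1-fold lower number from compound 1 to compound 2 (0.06 log units; that floor lies within the scatter), concerns the end of the chain on that oxygen. None of the three shows a change beyond the scatter, so no step beyond the scatter is expected in this assay, and these data give no direction for one. The expected step is a step that the limit leaves unreadable from compound 3 to compound 4. The value estimated for compound 4 is 12000 nM. The expected range for compound 4 runs from 6000 nM to 30000 nM, and a report as a limit alone is the likelier outcome.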

Compound 4, half-maximal inhibitory concentration: > 10000 nM
Compound 4 ended at the assay's limit; the forecaster's own chance of this, stated with the estimate: 65%; the middle value lies beyond the limit too.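

The exchange of vinyl for 3-methoxyphenyl on a carbonyl carbon brings in 8 heavy atoms and a six-membered aromatic ring where 2 heavy atoms stood, yet compound 4, like compound 3, gives only a limit in this assay, and no true number appears at this position. The steps to compound 4 from compound 3 and from compound 1 cannot be read, as both ends of each are limits. The one readable comparison is an at least 1.1-fold higher number from compound 2 to compound 4 (0.06 log units; that floor lies within the scatter), so no separation beyond the scatter appears, and the count at the limit has grown: the limit of > 10000 nM in this assay, at which 3 of the 4 values shown sit.

How far compounds 1, 3 and 4 lie past that limit stays open, so the compounds shown cannot rank the groups on this oxygen against one another. As far as these compounds go, it also stays open whether an amine or a carboxylic acid on the 3-methoxyphenyl ring, or a longer chain in place of that ring on the carbonyl carbon, would give a true number in this assay.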